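This account rests on a few compounds, and the source may have more. Where it says the series, first, only, none or still open, it means among the compounds named here.

Compound 1 `Clc1cccc(-n2ncnc2Nc2ccccc2)c1Cl`: in a functional assay for antagonist activity at P2X purinoceptor 7 (Rattus norvegicus), read by FLIPR and calcium flux (on this read-out lower numbers stand for stronger inhibition and higher numbers for weaker inhibition), compound 1 gives 3890 nM.
Compound 2 `COc1ccccc1Nc1ncnn1-c1cccc(Cl)c1Cl`: in this assay compound 2 gives 2040 nM.
Compound 3 `FC(F)(F)Oc1ccccc1Nc1ncnn1-c1cccc(Cl)c1Cl`: in this assay compound 3 gives 5500 nM.

Among these three, compound 1 holds the second highest number. Its nearest neighbour is compound 3, a 1.4-fold higher number from compound 1 to compound 3 (0.15 log units; within the scatter), and compound 2 lies at a 1.9-fold lower number from compound 1 to compound 2 (0.28 log units; within the scatter); both gaps are within the scatter. Compound 4 `Clc1cccc(-n2ncnc2NCc2ccccc2)c1Cl` is not yet measured; it differs from compound 1 by benzyl in place of phenyl on a nitrogen on an aromatic ring. Going by the values given here, no measured step touches this nitrogen: the only change beyond the scatter, a 2.7-fold higher number from compound 2 to compound 3 (0.43 log units; beyond the scatter), and the two smaller ones all concern groups on an aromatic carbon. Among the compounds with values here, with no comparable step in hand, the expected step in this assay is a 1.3-fold higher number from compound 1 to compound 4 (0.11 log units; within the scatter), little beyond the scatter but with wide uncertainty. Compound 4 is therefore estimated at 5000 nM, ranging from 1500 nM to 20000 nM.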

Compound 4, half-maximal inhibitory concentration: 209 nM
Compound 4: the middle estimate sits 24-fold (1.38 log units) above what was measured; measured number below the stated range.
By their numbers in this assay, from the lowest: compound 4; then compounds 2, 1 and 3 (each within the scatter of the next, the first and the last beyond it).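

Benzyl in place of phenyl on this nitrogen gives a 19-fold lower number from compound 1 to compound 4 (1.27 log units; beyond the scatter) in this assay, a step much larger than a 2.7-fold higher number from compound 2 to compound 3 (0.43 log units; beyond the scatter), the only step beyond the scatter among the earlier compounds. The aromatic ring of carbon remains in both groups, yet this single change at the nitrogen carries far more weight than the changes shown on an aromatic carbon. The data offer no explanation for the size of this step.

As far as these compounds go, whether a longer chain such as phenethyl would hold this gain on the nitrogen remains open. So does whether methoxy or trifluoromethoxy on the benzyl ring of compound 4 would shift the number.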